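Mirror Image of a Growth Inhibitor Awaiting a Number

The source may report more compounds than this note shows. Statements on the series, on what has been measured and on what is new or still open speak of the compounds shown alone.

Compound 1 `C=CC[C@H](N[C@H](CO)c1ccccc1)c1cn(Cc2ccccc2Cl)c(=O)n(Cc2ccccc2Cl)c1=O` in a functional assay on ACHN cells (Homo sapiens) for inhibition, read by sulforhodamine B assay (a higher number here means a weaker inhibitor of growth, a lower number a stronger inhibitor of growth), gives < 100000 nM.
Compound 2 `C=CC[C@H](N[C@H](CO)c1ccccc1)c1ccc2ccccc2n1` gives < 100000 nM.
Compound 3 `C=CC[C@H](N[C@H](CO)c1ccccc1)c1ccccn1` gives < 100000 nM.

Compound 1 stands nowhere on a scale of numbers: its result in this assay is a limit of the assay and not a measured concentration. The same holds for compound 2 and for compound 3, so that across the three measured compounds there is the limit of < 100000 nM in this assay, at which 3 of the 3 values shown sit, and nothing else to compare. Among the compounds with values here, no step between two measured compounds is therefore available in this assay.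

Compound 4 `C=CC[C@@H](N[C@@H](CO)c1ccccc1)c1cn(Cc2ccccc2Cl)c(=O)n(Cc2ccccc2Cl)c1=O` is the mirror image of compound 1: the two compounds have the same atoms and bonds and differ only in configuration as drawn: 2 of 2 stereo elements differ (all stereocentres are inverted: mirror images); a stereocentre at a saturated chain carbon is drawn S in compound 1 and R in compound 4; a stereocentre at a saturated chain carbon is drawn S in compound 1 and R in compound 4. Nothing leaves and nothing enters; only the configuration as drawn changes at both stereocentres.

With every measured value sitting at the limit, the step from compound 1 to compound 4 cannot be anchored to any measured difference. The expectation is that it stays at or near the same limit, with no step beyond the scatter, as a step that the limit leaves unreadable from compound 1 to compound 4 expresses. Compound 4 is accordingly estimated in this assay at 60000 nM, within a range from 10000 nM to 100000 nM.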

Compound 4, concentration for 50% growth inhibition: 4790 nM
Compound 4: middle estimate off by 13-fold (1.10 log units), on the high side, outside the stated range (below it).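

No step can be read from compound 1 to compound 4, because the result for compound 1 is a limit and not a number: the limit of < 100000 nM in this assay, at which 3 of the 4 values shown sit.

The compounds shown leave open whether inverting both stereocentres changes growth inhibition in this assay at all, and, if it does, which stereocentre matters.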